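One aryl swap on the shared core, and its expected cost

A few compounds are considered here, and "the series" means these few. Any claim that something is new, unique, unknown or untested is made for them only; others in the source may bear on it.

Compound 1 `COc1ccc(C(=O)c2cc(OC)c(OC)c(OC)c2)cc1NC(=O)/C=C/c1cccc(OC(F)(F)F)c1`: in a functional assay on B16 cells (Mus musculus) for cytotoxicity, read by MTT assay, with a stated time of 72 h (on this read-out higher numbers stand for weaker inhibition and lower numbers for stronger inhibition), compound 1 gives 6300 nM.
Compound 2 `COc1ccc(C(=O)c2cc(OC)c(OC)c(OC)c2)cc1NC(=O)/C=C/c1ccc(F)c(F)c1`: compound 2 gives 6500 nM.
Compound 3 `COc1cc(C(=O)c2cc(OC)c(OC)c(OC)c2)cc(NC(=O)/C=C/c2cc(OC)c(OC)c(OC)c2)c1OC`: compound 3 gives 2500 nM.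

Among these three numbers compound 3 stands lowest, with compound 1 and compound 2 both giving higher numbers by more than the usual scatter. Compound 4 `COc1cc(C(=O)c2cc(OC)c(OC)c(OC)c2)cc(NC(=O)/C=C/c2ccc(C(F)(F)F)cc2)c1OC` differs from compound 3 in one place: 4-(trifluoromethyl)phenyl in place of 3,4,5-trimethoxyphenyl on a double-bonded chain carbon bound to a double-bonded chain carbon. Going by the values given here, the only measured step at the same place is the one between compound 1 and compound 2, a 1.0-fold higher number from compound 1 to compound 2 (0.01 log units; within the scatter), where one fluorinated aryl replaced another on a different core and the number did not move. That step says little about replacing a methoxylated aryl by a fluorinated one. Compound 1 and compound 2, which both carry a fluorinated aryl at this place, sit higher than compound 3; on this basis a moderately higher number is expected for compound 4, with an expected step of a 2.0-fold higher number from compound 3 to compound 4 (0.30 log units; within the scatter). The estimate for compound 4 is 5000 nM, ranging from 2000 nM to 14000 nM.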

Compound 4, half-maximal inhibitory concentration: 3300 nM
Beside the measured number, compound 4's estimate is 1.5-fold (0.18 log units) above it; measured number inside the range.
By their numbers in this assay, from the lowest: compounds 3, 4, 1 and 2 (each within the scatter of the next, the first and the last beyond it).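

In this assay the exchange of 3,4,5-trimethoxyphenyl for 4-(trifluoromethyl)phenyl on a double-bonded chain carbon bound to a double-bonded chain carbon comes to a 1.3-fold higher number from compound 3 to compound 4 (0.12 log units; within the scatter) and leaves the two compounds indistinguishable on this read-out. The earlier step at this place had only put one fluorinated aryl for another on a different core, whereas this one shows that on the core of compound 3 the methoxylated aryl, with its 3 hydrogen-bond acceptors, can give way to an aryl with 0 without a change beyond the scatter. Nothing shown bears on why the number holds across this exchange.

Going by these compounds, whether an aryl carrying an amine or a carboxylic acid would hold the number at this place remains open. So does the outcome of putting 3,4,5-trimethoxyphenyl at this place on the core of compound 1.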